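Methylated Aniline Variant of a Chlorinated Acrylamide Core

This account rests on a few compounds, and the source may have more. Where it says the series, first, only, none or still open, it means among the compounds named here.

compound 1 `C=CC(=O)Nc1cc(Nc2ncc(Cl)c(Nc3ccccc3S(=O)(=O)C(C)C)n2)c(OC)cc1N1CCN(C)CC1` — 43 nM
compound 2 `C=CC(=O)Nc1cc(Nc2ncc(Cl)c(Nc3c(F)cccc3F)n2)c(OC)cc1N1CCN(C)CC1` — 130 nM

Both compounds were tested in a functional assay on NCI-H1975 cells (Homo sapiens) for inhibition, read by CellTiter-Glo, with a stated time of 72 h; a lower number here means a stronger inhibitor of growth, a higher number a weaker inhibitor of growth. In it compound 1 gives 43 nM and compound 2 gives 130 nM, the higher of the two numbers. Among the measured compounds shown here, the one measured step, a 3.0-fold higher number from compound 1 to compound 2 (0.48 log units; beyond the scatter), shows that exchanging the aryl group attached to the shared core moves the readout by a modest amount. Compound 3 `C=CC(=O)Nc1cc(Nc2ncc(Cl)c(N(C)c3cccc(C(F)(F)F)c3)n2)c(OC)cc1N1CCN(C)CC1` differs from compound 2 in a single place: methyl(3-(trifluoromethyl)phenyl)amino in place of (2,6-difluorophenyl)amino on an aromatic carbon. The earlier step is the only one that bears on this change, since it also exchanged the aryl group on the same carbon of the core, and it was modest in size. For the measured compounds named here, the new change goes further, trading the amine hydrogen for a methyl and bringing in a trifluoromethyl group, and no measured step covers either part. A modest weakening is therefore expected, a 2.3-fold higher number from compound 2 to compound 3 (0.36 log units; beyond the scatter), with real uncertainty in both directions. Compound 3 is estimated at 300 nM in this assay, within a range from 90 nM to 1000 nM.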

Compound 3, concentration for 50% growth inhibition: 1800 nM
Beside the measured number, compound 3's estimate is 6.0-fold (0.78 log units) below it; the measured number lies above the stated range.
By their numbers in this assay, from the lowest: compound 1; then compound 2; then compound 3.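

In this assay, the step of a 14-fold higher number from compound 2 to compound 3 (1.14 log units; beyond the scatter) is far larger than the earlier exchange of one aryl group for another, a 3.0-fold higher number from compound 1 to compound 2 (0.48 log units; beyond the scatter), so the group on this aromatic carbon next to the ring nitrogen can change the readout by much more than that first step suggested. This change is a bundle, however: the linking nitrogen goes from carrying a hydrogen to carrying a methyl, so the count of hydrogen-bond donors in the group falls from 1 to 0, while the 2,6-difluorophenyl ring is replaced by a 3-(trifluoromethyl)phenyl ring, and this single step cannot assign the loss of growth inhibition to either part. No measurement is available here that would explain why the number rose so much.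

The compounds shown leave open which part of the change matters more: a (3-(trifluoromethyl)phenyl)amino group, with the hydrogen kept, and a methyl(2,6-difluorophenyl)amino group would each isolate one part. From the compounds shown here alone, it also remains open how a different small group on that nitrogen, such as ethyl, would compare with methyl.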